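Compound 4 Against the Measured Series of Thromboxane Synthase Inhibitors

The source may report more compounds than this note shows. Statements on the series, on what has been measured and on what is new or still open speak of the compounds shown alone.

Of the compounds shown here, three have been measured in an assay for inhibition of Thromboxane-A synthase (Homo sapiens), using microsomes; on this read-out lower numbers stand for stronger inhibition and higher numbers for weaker inhibition. Compound 1 `CC(C)(C)c1ccc(OC(C)(C)C2OCC(C/C=C\CCC(=O)O)C(c3cccnc3)O2)cc1` gives 280 nM, compound 2 `CC(C)(Oc1ccc(F)cc1)C1OCC(C/C=C\CCC(=O)O)C(c2cccnc2)O1` gives 51 nM, and compound 3 `CC(C)(Oc1ccc(F)cc1[N+](=O)[O-])C1OCC(C/C=C\CCC(=O)O)C(c2cccnc2)O1` gives 20 nM. Compound 3 stands at the lowest number of the three, with compound 2 nearest and compound 1 furthest; the step of a 14-fold lower number from compound 1 to compound 3 (1.15 log units; beyond the scatter) and the step of a 2.6-fold lower number from compound 2 to compound 3 (0.41 log units; beyond the scatter) both lie beyond the scatter, so compound 3 is the strongest inhibitor measured so far.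

Compound 4 `Cc1ccc(SC(C)(C)C2OCC(C/C=C\CCC(=O)O)C(c3cccnc3)O2)c([N+](=O)[O-])c1` differs from compound 3 by a group of 11 heavy atoms (7 carbon, 1 nitrogen, 2 oxygen, 1 sulfur; one six-membered aromatic ring of carbon only) in place of a group of 11 heavy atoms (6 carbon, 1 nitrogen, 3 oxygen, 1 fluorine; one six-membered aromatic ring of carbon only), on a saturated chain carbon bound to two saturated chain carbons and a saturated ring carbon. Within the data shown here, none of the measured steps matches this change directly. The step of a 5.5-fold lower number from compound 1 to compound 2 (0.74 log units; beyond the scatter) and the step of a 2.6-fold lower number from compound 2 to compound 3 (0.41 log units; beyond the scatter) describe changes on the aromatic ring that is replaced here, and the nitro group present in compound 3 is retained in the group that enters. Nothing measured speaks to the exchange of oxygen for sulfur or of fluorine for a methyl. With the nitro kept and the ring otherwise similar, a step of modest size at most is expected, in either direction, a 1.5-fold higher number from compound 3 to compound 4 (0.18 log units; within the scatter). Compound 4 is therefore estimated at 30 nM, with a range from 10 nM to 90 nM in this assay.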

Compound 4, half-maximal inhibitory concentration: 30 nM
Beside the measured number, compound 4's estimate shows no gap at the digits printed, and the stated range covers the measured number.
By their numbers in this assay, from the lowest: compounds 3, 4 and 2 (each within the scatter of the next, the first and the last beyond it); then compound 1.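

In this assay the place on a saturated chain carbon bound to two saturated chain carbons and a saturated ring carbon takes sulfur for the oxygen and a methyl for the fluorine, with the nitro kept, and the number stays within the scatter (a 1.5-fold higher number from compound 3 to compound 4 (0.18 log units; within the scatter)). Compound 4 also stays within the scatter of the compound without a nitro (a 1.7-fold lower number from compound 2 to compound 4 (0.23 log units; within the scatter)), although the nitro step from compound 2 to compound 3 lay beyond it, so the new result blurs the separation between those two compounds. The group carrying the tert-butyl remains clearly apart from the entering group (a 9.3-fold lower number from compound 1 to compound 4 (0.97 log units; beyond the scatter)). No supporting evidence is available to explain these numbers.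

The sulfur and the methyl enter together, so the compounds shown do not give the contribution of either exchange alone. They also leave open how the number would respond to an amine or a carboxylic acid in place of the nitro, or to a methylene in place of the sulfur.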